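Rearranging One Side Chain in an Antiproliferative Series

The source may report more compounds than this note shows. Statements on the series, on what has been measured and on what is new or still open speak of the compounds shown alone.

- Compound 1 `CCCC1=C(OC)C(CCC)(CCC)C(=O)/C(=C(O)\C=C\c2ccccc2)C1=O` with 4.6 uM
- Compound 2 `CCCC1=C(OCC(C)C)C(CCC)(CCC)C(=O)/C(=C(O)\C=C\c2ccccc2)C1=O` with 4.8 uM

For the measured compounds named here, both values come from a functional assay on KB cells (Homo sapiens) for antiproliferative activity, read by sulforhodamine B assay, with a stated time of 3 days (a higher number here means that more compound is needed for the effect, a lower number that less compound is needed), and lie within the usual scatter of each other, so compound 2 stands level with compound 1, the only other measured compound.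

Compound 3 `CCCCOC1=C(CCC)C(=O)/C(=C(O)/C=C/c2ccccc2)C(=O)C1(CCC)CCC` holds the same atoms as compound 2, joined differently. The change is propyl in place of isopropyl on a saturated chain carbon bound to an oxygen on an unsaturated carbon and amounts to propyl in place of isopropyl on a saturated chain carbon bound to an oxygen on an unsaturated carbon, turning isobutoxy into butoxy.

Going by the values given here, only one measured step bears on this, a 1.0-fold higher number from compound 1 to compound 2 (0.02 log units; within the scatter) at the same place, with isopropyl in place of hydrogen. It stayed within the scatter, and one step is thin evidence, but no step beyond the scatter is expected in this assay here. The expected change is an estimated 1.0-fold lower number from compound 2 to compound 3 (0.01 log units; within the scatter) and no larger. Compound 3 is estimated at 4.7 uM with an expected range from 2.6 uM to 8.5 uM for most repeat measurements.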

Compound 3, concentration for half-maximal effect: 8 uM
Estimate against measurement, compound 3: 1.7-fold (0.23 log units) below; low and high end bracket the measured number.
By their numbers in this assay, from the lowest: compounds 1, 2 and 3 (each within the scatter of the next).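

Turning the branched isobutoxy chain into the straight butoxy chain, with the same atoms simply joined differently, gives a step that stays within the scatter in this assay (a 1.7-fold higher number from compound 2 to compound 3 (0.22 log units; within the scatter)). The larger change at this place, propyl in place of hydrogen, also stays within the scatter (a 1.7-fold higher number from compound 1 to compound 3 (0.24 log units; within the scatter)), so across these three compounds neither the branching nor the added chain carbons separate the numbers. Nothing available here explains these results.

The compounds shown leave open whether this place would give the same picture with an amine or a carboxylic acid at the end of the chain, or with a much longer chain such as decyloxy. From the compounds shown here alone, the rest of the core stays the same throughout, so what a change elsewhere would do also remains open.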